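Methyl-to-hydrogen step on the benzylamide aryl ring

The compounds below may be only part of what the source reports. "The series", "measured", "known", "first", "only" and "open" are said of these compounds alone.

Measured so far:
compound 1 `Cc1ccc(CNC(=O)c2nc(-c3ccc(F)cc3)n(CC[C@@H](O)C[C@@H](O)CC(=O)O)c2C2CC2)cc1` gives 178 nM in a functional assay on L6 cells (Rattus norvegicus) for inhibition, read by scintillation counting, with a stated time of 3 h; a higher number here means a weaker inhibitor, a lower number a stronger inhibitor
compound 2 `O=C(O)C[C@H](O)C[C@H](O)CCn1c(-c2ccc(F)cc2)nc(C(=O)NCc2ccc(F)cc2)c1C1CC1` gives 1620 nM in this assay

Compound 1 holds the lowest of the two numbers measured in this assay; its nearest neighbour is compound 2, reached by a 9.1-fold higher number from compound 1 to compound 2 (0.96 log units; beyond the scatter), a change of fluoro in place of methyl on an aromatic carbon.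

Compound 3 `O=C(O)C[C@H](O)C[C@H](O)CCn1c(-c2ccc(F)cc2)nc(C(=O)NCc2ccccc2)c1C1CC1` has not yet been measured. Its difference from compound 1 is hydrogen in place of methyl on an aromatic carbon, that is, 4-methylbenzyl to benzyl on the amide side of the shared core.

Among the measured compounds shown here, the only measured step at this position is the one from compound 1 to compound 2, where fluoro replaced methyl and the number rose by a 9.1-fold higher number from compound 1 to compound 2 (0.96 log units; beyond the scatter). For the measured compounds named here, no step from methyl to hydrogen is available here, so the expectation rests on that single exchange at the same aromatic carbon. Going by the values given here, removing the methyl is expected to move the number upward, though probably by less than the fluoro exchange did, since only that one step is known at all.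

For compound 3 the estimate in this assay is 600 nM, within 200 nM to 2500 nM. This expected step from compound 1 to compound 3 is a 3.4-fold higher number from compound 1 to compound 3 (0.53 log units; beyond the scatter).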

Compound 3, half-maximal inhibitory concentration: 632 nM
Compound 3: middle estimate off by 1.1-fold (0.02 log units), on the low side; the range from low to high includes it.
By their numbers in this assay, from the lowest: compound 1; then compound 3; then compound 2.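

In this assay, taking the methyl away alone gives a 3.6-fold higher number from compound 1 to compound 3 (0.55 log units; beyond the scatter), so the 4-methylbenzyl to benzyl change accounts for part of the gap seen earlier between methyl and fluoro at this aromatic carbon. Hydrogen in place of fluoro gives a 2.6-fold lower number from compound 2 to compound 3 (0.41 log units; beyond the scatter), which shows that fluoro is not equivalent to hydrogen here and places the benzyl amide of compound 3 between the other two, with compound 1 lowest and compound 2 highest, all steps beyond the scatter. Nothing available explains this order of methyl, hydrogen and fluoro.

Going by these compounds, three compounds fix only that order at one carbon, so it remains open where an ethyl, a chloro, a methoxy or a trifluoromethyl group would fall relative to compound 1 and compound 3. On these data alone, it is also open whether the same order would hold with the methyl, hydrogen and fluoro set on a different amide side chain, such as a phenethyl amide in place of the benzyl amide.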